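This account rests on a few compounds, and the source may have more. Where it says the series, first, only, none or still open, it means among the compounds named here.

The account begins with compound 1 `COc1cc(-c2nnc(SCC(=O)c3ccc(Cl)cc3)n2N)cc(OC)c1OC`, which was examined in a functional assay on PC-3 cells (Homo sapiens) for antiproliferative activity, read by MTT assay, with a stated time of 48 h; a lower number here means a stronger inhibitor, a higher number a weaker inhibitor. In this assay compound 1 gives > 100000 nM, which is a limit of the assay and not a number. Two further compounds share the core of compound 1 and differ only in the group on the aromatic ring. Compound 2 `COc1cc(-c2nnc(SCC(=O)c3ccc(C(F)(F)F)cc3)n2N)cc(OC)c1OC` gives in this assay > 100000 nM, again a limit of the assay. Compound 3 `COc1cc(-c2nnc(SCC(=O)c3ccc(F)cc3)n2N)cc(OC)c1OC` gives in this assay > 100000 nM, likewise a limit of the assay. The steps among them, a step that the two limits leave unreadable from compound 1 to compound 2, a step that the two limits leave unreadable from compound 1 to compound 3 and a step that the two limits leave unreadable from compound 2 to compound 3, therefore carry no readable size, since every value sits at the limit of > 100000 nM in this assay, at which 3 of the 3 values shown sit.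

Compound 4 `COc1cccc(NC(=O)CSc2nnc(-c3cc(OC)c(OC)c(OC)c3)n2N)c1` has not yet been measured. Its change from compound 1 is (3-methoxyphenyl)amino in place of 4-chlorophenyl on a carbonyl carbon. Going by the values given here, none of the measured steps touches the carbonyl carbon; they all concern the group on the aromatic ring, and each of them is unreadable. Among the compounds with values here, the measured steps thus give no guide to the size or direction of a change at this position, and the only anchor is that every compound so far sits at the limit. The writer therefore expects compound 4 to remain in the same region, a step of an at least 1.2-fold lower number from compound 1 to compound 4 (0.09 log units; that floor lies within the scatter), and estimates for compound 4 a value of 80000 nM, with a range from 15000 nM to 300000 nM, with a fair chance that this assay again reports only a limit.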

Compound 4, half-maximal inhibitory concentration: > 100000 nM
Compound 4: only a limit was reported; the forecaster's own chance of this, stated with the estimate: 65%; middle value at least 1.2-fold (0.09 log units) from the limit.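

In this assay compound 4 stays at the limit shared with compound 1, compound 2 and compound 3, so none of the steps to compound 4 can be read: the limit of > 100000 nM in this assay, at which 4 of the 4 values shown sit.

The compounds shown leave open whether any change on the aromatic ring or on the carbonyl carbon would give a readable value in this assay.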